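Enantiomer step at the ring stereocentre of compound 2

This account rests on a few compounds, and the source may have more. Where it says the series, first, only, none or still open, it means among the compounds named here.

Of the compounds shown here, two carry numbers so far. Compound 1 `CN(C)C[C@H]1CN(C)C(=O)O1` in an assay on Hippocampus for displacement of a labelled ligand from Neuronal acetylcholine receptor; alpha4/beta2 (Rattus norvegicus) (on this read-out higher numbers stand for weaker inhibition and lower numbers for stronger inhibition), gives 2200 nM. Compound 2 `CN1C[C@@H](C[N+](C)(C)C)OC1=O` in this assay gives 3610 nM. On these two figures compound 2 carries the larger one, but its distance from compound 1 lies inside the usual scatter, so the two cannot be ranked against each other; compound 1 and compound 2 also differ in more than one place, and nothing beyond their two values is known about them as a pair.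

Compound 3 `CN1C[C@H](C[N+](C)(C)C)OC1=O` is the next compound to be measured in this assay. The change from compound 2 is the two compounds have the same atoms and bonds and differ only in configuration as drawn: 1 of 1 stereo elements differ; a stereocentre at a saturated ring carbon is drawn S in compound 2 and R in compound 3. Among the compounds with values here, no measured pair differs only in configuration, so no step of this kind is available as a guide. From the compounds shown here alone, a change of configuration can move a number in either direction, and its size here is unknown. The step from compound 2 to compound 3 is therefore expected to be a 1.0-fold lower number from compound 2 to compound 3 (0.01 log units; within the scatter), with wide uncertainty in both directions. Compound 3 is expected to give about 3500 nM, with the estimate ranging from 700 nM to 18000 nM.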

Compound 3, inhibition constant: 3100 nM
Compound 3: the middle estimate sits 1.1-fold (0.05 log units) above what was measured; low and high end bracket the measured number.
By their numbers in this assay, from the lowest: compounds 1, 3 and 2 (each within the scatter of the next).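

Compounds 2 and 3 give the series its first reading of configuration alone at the saturated ring carbon: the fact that compounds 2 and 3 differ only in the configuration as drawn. In this assay the exchange of S for R at this stereocentre gives a 1.2-fold lower number from compound 2 to compound 3 (0.07 log units; within the scatter), so the two drawn configurations cannot be told apart on this read-out while the group of 4 heavy atoms is present. Within the data shown here, compound 3 also provides the first single-place reading at the saturated chain carbon bound to the saturated ring carbon: the group of 4 heavy atoms (3 carbon, 1 nitrogen; no ring) in place of the group of 3 heavy atoms (2 carbon, 1 nitrogen; no ring) gives a 1.4-fold higher number from compound 1 to compound 3 (0.15 log units; within the scatter), which likewise separates neither compound from the other.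

The compounds shown leave open whether configuration at the ring stereocentre would also make no readable difference with the group of 3 heavy atoms in place. They also leave open how this assay would respond to a primary amine or a longer chain at the saturated chain carbon, since the two groups shown are the only ones read there.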